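Trifluoromethoxy for Trifluoromethyl on the Sulfonyl Aryl

A few compounds are considered here, and "the series" means these few. Any claim that something is new, unique, unknown or untested is made for them only; others in the source may bear on it.

Three compounds share a core in which a dimethylaminophenyl and a second aryl group sit on a ring closed by a sulfonyl-bearing nitrogen. Compound 1 `CN1CCN(c2ccc(C3=NN(S(=O)(=O)c4ccc(OC(F)(F)F)cc4)C(c4ccc(N(C)C)cc4)C3)cc2)CC1` gives 10.6% in a functional assay on MDA-MB-231 cells (Homo sapiens) for inhibition, read by sulforhodamine B assay, tested at 10 uM; on this read-out lower numbers stand for less inhibition and higher numbers for more inhibition at the one concentration tested (going by the name of the read-out). Compound 2 `CN(C)c1ccc(C2CC(c3ccc(-n4cncn4)cc3)=NN2S(C)(=O)=O)cc1` gives 7.8%, and compound 3 `CN(C)c1ccc(C2CC(c3ccc(-n4cncn4)cc3)=NN2S(=O)(=O)c2ccc(C(F)(F)F)cc2)cc1` gives 15.3%. Compound 3 has the highest of the three numbers, yet it lies within the scatter of both others, so no ordering among them can be claimed. For the measured compounds named here, the one single-point step measured so far, a number 7.5 percentage points higher from compound 2 to compound 3 (within the scatter), is also within the scatter.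

Compound 4 `CN(C)c1ccc(C2CC(c3ccc(-n4cncn4)cc3)=NN2S(=O)(=O)c2ccc(OC(F)(F)F)cc2)cc1` differs from compound 3 at the aryl group on the sulfonyl sulfur: trifluoromethoxy in place of trifluoromethyl on an aromatic carbon. Going by the values given here, no measured step covers this exact exchange. Compound 1 carries the same 4-(trifluoromethoxy)phenyl on its sulfonyl sulfur but differs elsewhere, so its value only shows that this group is compatible with low inhibition. Given that compound 2 and compound 3 moved by a number 7.5 percentage points higher from compound 2 to compound 3 (within the scatter), a much larger sulfonyl substituent change than the present one, the step of a number 2.3 percentage points lower from compound 3 to compound 4 (within the scatter) is expected to stay within the scatter. Compound 4 is therefore estimated at 13%, in a range from 2% to 26%.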

Compound 4, a percentage reported as inhibition, at one concentration (the size of the read-out at that concentration, not a potency): 18.5%
Beside the measured number, compound 4's estimate is 5.5 percentage points below it; measured number inside the range.
By their numbers in this assay, from the lowest: compounds 2, 1, 3 and 4 (each within the scatter of the next, the first and the last beyond it).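

In this assay, putting trifluoromethoxy in place of trifluoromethyl on the aryl group of the sulfonyl sulfur gives a number 3.2 percentage points higher from compound 3 to compound 4 (within the scatter), so the added oxygen produces no change that can be told apart from ordinary variation between repeats. The sulfonyl position does now show its first step that clears the scatter, a number 10.7 percentage points higher from compound 2 to compound 4 (beyond the scatter), for 4-(trifluoromethoxy)phenyl in place of methyl, although the effect is modest and cannot be credited to trifluoromethoxy over trifluoromethyl, since compound 3 and compound 4 remain unresolved. At the other end of the molecule, 1H-1,2,4-triazol-1-yl in place of 4-methylpiperazin-1-yl on an aromatic carbon gives a number 7.9 percentage points higher from compound 1 to compound 4 (within the scatter), so that exchange has no resolved effect with the 4-(trifluoromethoxy)phenyl group in place.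

Nothing available explains why these numbers fall where they do. Still open is whether an amine or a carboxylic acid in place of trifluoromethoxy on that aryl group would change the inhibition, and how any of these compounds would behave at concentrations other than the single one used here.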